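Swapping the side chain on the triazole of a coumarin series

The compounds below may be only part of what the source reports. "The series", "measured", "known", "first", "only" and "open" are said of these compounds alone.

Among the measured compounds shown here, compound 2 `O=c1cc(Cn2cc(CCc3ccccc3)nn2)c2ccc(O)cc2o1` is the only compound here with an actual number: in a functional assay on HepG2 cells (Homo sapiens) for inhibition, read by MTT assay, with a stated time of 72 h (a higher number here means a weaker inhibitor, a lower number a stronger inhibitor), compound 2 gives 50500 nM. Compound 1 `CC(O)c1cn(Cc2cc(=O)oc3cc(O)ccc23)nn1` differs from it only at the same position on the five-membered ring, and there compound 1 gives > 100000 nM, which is a limit of this assay, not a number; that is the limit of > 100000 nM in this assay, at which 1 of the 2 values shown sits. For the measured compounds named here, the step of an at least 1.9-fold lower number from compound 1 to compound 2 (0.29 log units; that floor lies within the scatter) is therefore the only measured step, and it tells little about direction. Compound 3 `O=c1cc(Cn2cc(-c3cc(F)cc(F)c3)nn2)c2ccc(O)cc2o1` carries the change (3,5-difluorophenyl in place of phenethyl on an aromatic carbon). Going by the values given here, no measured step tests an aromatic group at this position, so the expectation rests on the one step seen, which did not clearly move the number. Compound 3 is therefore expected to stay close to compound 2, with the step of a 1.0-fold lower number from compound 2 to compound 3 (0.00 log units; within the scatter) not beyond the scatter, giving an estimated 50000 nM with a range from 15000 nM to 150000 nM.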

Compound 3, half-maximal inhibitory concentration: 38900 nM
Compound 3: middle estimate off by 1.3-fold (0.11 log units), on the high side; low and high end bracket the measured number.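

Replacing phenethyl with 3,5-difluorophenyl gives a 1.3-fold lower number from compound 2 to compound 3 (0.11 log units; within the scatter), so in this assay an aromatic ring attached without the chain does as well as one carried on it. Among the compounds shown here, replacing 1-hydroxyethyl with the same group gives an at least 2.5-fold lower number from compound 1 to compound 3 (0.41 log units; beyond the scatter), the first step at this position that is printed as beyond the scatter, which suggests that the aromatic group reads better here than the small 1-hydroxyethyl. Compound 1 stands at a limit of the assay, not a number, so this step gives only a minimum size: the limit of > 100000 nM in this assay, at which 1 of the 3 values shown sits.

The compounds shown leave open what a plain phenyl at this position would give, and so whether the two fluorines matter at all. On these data alone, how an amine or a carboxylic acid at this position would read also remains open.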